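Swapping a tert-butyl amide for a cyclohexyl amide

This account rests on a few compounds, and the source may have more. Where it says the series, first, only, none or still open, it means among the compounds named here.

Compound 1 `C=CC1=C(C(=O)NC(C)(C)C)C(c2ccc(OC)cc2)OC1`: in a functional assay on A549 cells (Homo sapiens) for cytotoxicity, read by MTT assay, with a stated time of 24 h (a lower number here means a stronger inhibitor, a higher number a weaker inhibitor), compound 1 gives > 100000 nM, which is a limit of the assay and not a number.
Compound 2 `C=CC1=C(C(=O)NC(C)(C)C)C(c2ccc(F)cc2)OC1`: in this assay compound 2 gives > 100000 nM, again a limit.

Compound 1 therefore stands at the limit of > 100000 nM in this assay, at which 2 of the 2 values shown sit, with no exact value known. Compound 3 `C=CC1=C(C(=O)NC2CCCCC2)C(c2ccc(OC)cc2)OC1` differs from it by cyclohexyl in place of tert-butyl on an amide-type nitrogen. Going by the values given here, the one measured step, a step that the two limits leave unreadable from compound 1 to compound 2, changes a different part of the molecule and, sitting between two limits, cannot be sized. Among the compounds with values here, no measured step bears directly on the amide substituent. With both known compounds at the limit, compound 3 is expected to give a limit as well, estimated at 150000 nM (range 50000 nM to 500000 nM), so the expected step is a step that the limit leaves unreadable from compound 1 to compound 3.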

Compound 3, half-maximal inhibitory concentration: > 100000 nM
Compound 3 gave a limit, no number; the forecaster's own chance of this, stated with the estimate: 85%; the middle value does not contradict the limit.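

Compound 1 and compound 3 both give a limit and not a number, so the step between them cannot be read: the limit of > 100000 nM in this assay, at which 3 of the 3 values shown sit.

Whether the amide substituent changes anything in this assay stays open, with no exact value for any compound shown.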